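A few compounds are considered here, and "the series" means these few. Any claim that something is new, unique, unknown or untested is made for them only; others in the source may bear on it.

Measured so far in a functional assay on MCF7 cells (Homo sapiens) for inhibition, read by CCK-8 assay, with a stated time of 48 h; a higher number here means a weaker inhibitor of growth, a lower number a stronger inhibitor of growth:
Compound 1 `CN1CCN(c2ccc(Nc3ncc(Cl)c(Nc4ccccc4)n3)nc2)CC1`: 51800 nM
Compound 2 `COc1ccccc1CNc1nc(Nc2ccc(N3CCN(C)CC3)cn2)ncc1Cl`: > 100000 nM (a limit of the assay, not a number)
Compound 3 `CC(C)c1ccc(Nc2nc(Nc3ccc(N4CCN(C)CC4)cn3)ncc2Cl)cc1`: 1880 nM

Compound 3 has the lowest number of the three, which makes it the strongest growth inhibitor here, and compound 1 is its nearest neighbour. Compound 4 `COc1cccc(Nc2nc(Nc3ccc(N4CCN(C)CC4)cn3)ncc2Cl)c1` keeps the shared core but has 3-methoxyphenyl in place of 4-isopropylphenyl on a nitrogen on an aromatic ring.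

Three measured steps involve this part of the molecule. Adding isopropyl to the phenyl ring gave a 28-fold lower number from compound 1 to compound 3 (1.44 log units; beyond the scatter), a large step. Exchanging 2-methoxybenzyl for 4-isopropylphenyl gave an at least 53-fold lower number from compound 2 to compound 3 (1.72 log units; beyond the scatter), also large, so the group on this nitrogen can matter a great deal. The remaining step, an at least 1.9-fold higher number from compound 1 to compound 2 (0.28 log units; that floor lies within the scatter), rests on a limit and says little.

For the measured compounds named here, compound 4 has no isopropyl group, and no measured step shows what a methoxy group does on a phenyl ring at this place. Part of the gain seen in a 28-fold lower number from compound 1 to compound 3 (1.44 log units; beyond the scatter) is therefore expected to be lost, with a higher number in this assay and a step beyond the scatter. The expected step is a 5.3-fold higher number from compound 3 to compound 4 (0.73 log units; beyond the scatter). For compound 4 the estimated value is 10000 nM, within an expected range from 2500 nM to 45000 nM.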

Compound 4, concentration for 50% growth inhibition: 7540 nM
The estimate for compound 4 lay 1.3-fold (0.12 log units) above the measured number, within the range that was stated.
By their numbers in this assay, from the lowest: compound 3; then compound 4; then compound 1. At a limit, above all of these: compound 2.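

In this assay, a methoxy group on the phenyl ring also gives a lower number, with a 6.9-fold lower number from compound 1 to compound 4 (0.84 log units; beyond the scatter), so the gain over the unsubstituted phenyl of compound 1 is not confined to the isopropyl group of compound 3. The two substituted rings still differ, with a 4.0-fold higher number from compound 3 to compound 4 (0.60 log units; beyond the scatter), but this change alters both the group and its place on the ring, so the step cannot show which of the two matters. The value of compound 2 is a limit and not a number, so the exchange of 2-methoxybenzyl for 3-methoxyphenyl, an at least 13-fold lower number from compound 2 to compound 4 (1.12 log units; beyond the scatter), gives only a floor, and it shows that a methoxy group alone does not decide the outcome: the limit of > 100000 nM in this assay, at which 1 of the 4 values shown sits.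

The compounds shown do not separate the effect of the group from the effect of its place on the phenyl ring. On these data alone, it also stays open whether an amine, a carboxylic acid or a chain longer than isopropyl on that ring would give a number lower than that of compound 3.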